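From Pyridin-2-yl to Pyridin-3-yl: A Small Expected Step

The source may report more compounds than this note shows. Statements on the series, on what has been measured and on what is new or still open speak of the compounds shown alone.

Of the compounds shown here, three sharing one core have been tested in a functional assay on MDA-MB-231 cells (Homo sapiens) for antiproliferative activity, read by sulforhodamine B assay, with a stated time of 48 h; on this read-out lower numbers stand for stronger inhibition of growth and higher numbers for weaker inhibition of growth. Compound 1 `COc1ccc(-c2cn(CCCN3C(=O)COc4ccccc43)nn2)cc1`, carrying 4-methoxyphenyl, gives 41500 nM. Compound 2 `CCCCCCc1cn(CCCN2C(=O)COc3ccccc32)nn1`, carrying hexyl, gives 1100 nM. Compound 3 `O=C1COc2ccccc2N1CCCn1cc(-c2ccccn2)nn1`, carrying pyridin-2-yl, gives 4800 nM, the middle of the three numbers.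

Compound 4 `O=C1COc2ccccc2N1CCCn1cc(-c2cccnc2)nn1` changes that same group: pyridin-3-yl in place of pyridin-2-yl on an aromatic carbon. It has the same atoms as compound 3, joined differently, with pyridin-3-yl in place of pyridin-2-yl on an aromatic carbon.

All three measured steps fall at this place. Hexyl in place of 4-methoxyphenyl gives a 38-fold lower number from compound 1 to compound 2 (1.58 log units; beyond the scatter), a large step. Pyridin-2-yl in place of 4-methoxyphenyl gives an 8.6-fold lower number from compound 1 to compound 3 (0.94 log units; beyond the scatter), and pyridin-2-yl in place of hexyl gives a 4.4-fold higher number from compound 2 to compound 3 (0.64 log units; beyond the scatter), both modest. So the group at this place can clearly move the number. Yet each of those swaps exchanges two different kinds of group, and none compares one pyridinyl group with another. The new swap is a much smaller edit, so no step beyond the scatter is expected, and the data give no firm direction.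

The estimated change is a 1.3-fold higher number from compound 3 to compound 4 (0.10 log units; within the scatter). For compound 4 the expected value is 6000 nM, with an estimated range from 2000 nM to 18000 nM.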

Compound 4, concentration for 50% growth inhibition: 3000 nM
Compound 4: middle estimate off by 2.0-fold (0.30 log units), on the high side; the measured number falls inside the stated range.
By their numbers in this assay, from the lowest: compound 2; then compounds 4 and 3 (each within the scatter of the next); then compound 1.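

In this assay, pyridin-3-yl in place of pyridin-2-yl gives a 1.6-fold lower number from compound 3 to compound 4 (0.20 log units; within the scatter), so this assay does not separate these two pyridinyl groups on the five-membered aromatic ring, even though the same atoms are joined differently. Compound 4 also stands in much the same place among the other compounds as compound 3 does: the swap from 4-methoxyphenyl gives a 14-fold lower number from compound 1 to compound 4 (1.14 log units; beyond the scatter), while the swap from hexyl gives a 2.7-fold higher number from compound 2 to compound 4 (0.44 log units; beyond the scatter). Across these four compounds, every step beyond the scatter exchanges two different kinds of group, and the one edit that only changes how the pyridinyl group is joined stays within it.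

No measurement shown here explains why the two pyridinyl groups read alike or why hexyl gives the lowest number of the four. Going by these compounds, it also remains open how a plain phenyl, a chain longer than hexyl, or an amine or carboxylic acid at the end of a chain would compare at this place.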